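The source may hold more compounds than are shown below. What is called first, only, known or untested is meant among the compounds shown, and "the series" means these compounds.

Series notes. For the measured compounds named here, compound 3 `COc1cc(-c2nn(-c3cccc(NC(=O)c4ccc(Cl)c(C(F)(F)F)c4)c3)cc2-c2ccncc2)ccc1Cl` gives 4130 nM in a functional assay on SF-539 cells (Homo sapiens) for inhibition, read by sulforhodamine B assay, with a stated time of 48 h (on this read-out lower numbers stand for stronger inhibition of growth and higher numbers for weaker inhibition of growth), the highest of the three numbers measured so far: compound 1 `COc1cc(-c2nn(-c3cccc(NC(=O)c4cccc(C(F)(F)F)c4)c3)cc2-c2ccncc2)ccc1Cl` gives 895 nM and compound 2 `COc1cc(-c2nn(-c3cccc(NC(=O)Nc4ccc(Cl)c(Cl)c4)c3)cc2-c2ccncc2)ccc1Cl` gives 965 nM. The unmeasured compound 4 `COc1cc(-c2nn(-c3cccc(NC(=O)c4ccccc4)c3)cc2-c2ccncc2)ccc1Cl` differs from compound 3 by phenyl in place of 4-chloro-3-(trifluoromethyl)phenyl on a carbonyl carbon. The step bearing most directly on this change is a 4.6-fold higher number from compound 1 to compound 3 (0.66 log units; beyond the scatter), where the chloro alone separates the two compounds; the step of a 4.3-fold higher number from compound 2 to compound 3 (0.63 log units; beyond the scatter) points in the same direction. Going by the values given here, no measured step removes the trifluoromethyl, so that part of the change has no precedent. Compound 4 is therefore expected to show a 4.1-fold lower number from compound 3 to compound 4 (0.62 log units; beyond the scatter), returning toward the level seen for compound 1. For compound 4 the estimate is 1000 nM, with a range from 400 nM to 3000 nM.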

Compound 4, concentration for 50% growth inhibition: 387 nM
Estimate against measurement, compound 4: 2.6-fold (0.41 log units) above, and the stated range ends above it.
By their numbers in this assay, from the lowest: compound 4; then compounds 1 and 2 (each within the scatter of the next); then compound 3.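

At the carbonyl carbon, phenyl gives the lowest number of the series in this assay, with an 11-fold lower number from compound 3 to compound 4 (1.03 log units; beyond the scatter) and a 2.5-fold lower number from compound 2 to compound 4 (0.40 log units; beyond the scatter). The new information is that hydrogen in place of trifluoromethyl, taken alone, also lowers the number, with a 2.3-fold lower number from compound 1 to compound 4 (0.36 log units; beyond the scatter), so among compounds 1, 3 and 4 each added group on this phenyl goes with a higher number. No measurement here offers an explanation for this trend.

Still open, on these data alone, is whether a smaller group on this phenyl, such as fluoro, methoxy or an amine, would keep the number of compound 4. Also open, as far as these compounds go, is how a plain phenylamino on the carbonyl carbon would compare.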